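From pyridin-2-yl to pyridin-3-yl on the carbonyl carbon

The compounds below may be only part of what the source reports. "The series", "measured", "known", "first", "only" and "open" are said of these compounds alone.

Compound 1 `O=C(c1ccccc1)N1CCC(NS(=O)(=O)c2cc(S(=O)(=O)c3ccccc3)ccc2C(F)(F)F)CC1` gives 70 nM in an assay on isolated protein for displacement of a labelled ligand from secreted frizzled-related protein 1 (Homo sapiens), read by fluorescence polarization, with a stated time of 30 min; on this read-out higher numbers stand for weaker inhibition and lower numbers for stronger inhibition.
Compound 2 `O=C(c1ccccn1)N1CCC(NS(=O)(=O)c2cc(S(=O)(=O)c3ccccc3)ccc2C(F)(F)F)CC1` gives 60 nM in this assay.

Compound 2 stands on one of two numbers that sit within the scatter of each other: the step of a 1.2-fold lower number from compound 1 to compound 2 (0.07 log units; within the scatter) is too small to separate the two compounds, so neither can be called the stronger.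

Compound 3 `O=C(c1cccnc1)N1CCC(NS(=O)(=O)c2cc(S(=O)(=O)c3ccccc3)ccc2C(F)(F)F)CC1` differs from compound 2 by pyridin-3-yl in place of pyridin-2-yl on a carbonyl carbon. The shared core, the sulfonamide, and the rest of the molecule stay the same; only the place of the ring nitrogen moves.

Within the data shown here, only one measured step bears on this part of the molecule, a 1.2-fold lower number from compound 1 to compound 2 (0.07 log units; within the scatter), where a phenyl was swapped for a pyridin-2-yl, and it stayed within the scatter. Among the measured compounds shown here, no measured step tells how the position of the nitrogen within that ring matters. For the measured compounds named here, with that single, flat step as the only guide, the expectation for compound 3 is a step of a 1.2-fold higher number from compound 2 to compound 3 (0.07 log units; within the scatter), that is, nothing beyond the scatter.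

The estimate for compound 3 in this assay is therefore 70 nM, with a range from 30 nM to 170 nM.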

Compound 3, half-maximal inhibitory concentration: 80 nM
Beside the measured number, compound 3's estimate is 1.1-fold (0.06 log units) below it, within the range that was stated.
By their numbers in this assay, from the lowest: compounds 2, 1 and 3 (each within the scatter of the next).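

In this assay, pyridin-3-yl in place of pyridin-2-yl on the carbonyl carbon gives a 1.3-fold higher number from compound 2 to compound 3 (0.12 log units; within the scatter), so this is the first measured sign that the place of the ring nitrogen makes no readable difference among these compounds. Pyridin-3-yl in place of phenyl gives a 1.1-fold higher number from compound 1 to compound 3 (0.06 log units; within the scatter), which means that phenyl, pyridin-2-yl and pyridin-3-yl all lie within the scatter of one another at this place, whether the ring holds a nitrogen or not, and whichever of these two places the nitrogen takes. No outside measurement is available to say why these three numbers lie so close together.

Going by these compounds, all three compounds carry a six-membered aromatic ring on this carbonyl carbon, so it remains open whether the number would shift beyond the scatter with a quite different group there, such as a ring bearing an amine or a carboxylic acid, or a plain alkyl chain in place of the ring. The compounds also share everything else, including the trifluoromethyl group and the sulfonamide, so they say nothing about how those parts of the molecule contribute.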